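Carboxy in place of methyl on the aryl hydrazone

The source may report more compounds than this note shows. Statements on the series, on what has been measured and on what is new or still open speak of the compounds shown alone.

The series shares one core, seen in compound 3 `Cc1cccc(N/N=C2\CCC(C)n3c2ncc(C(=O)O)c3=O)c1`. Among the compounds with values here, in a functional assay on the whole organism for inhibition, with Rattus norvegicus as the target (on this read-out lower numbers stand for an effect already at smaller amounts and higher numbers for an effect only at larger amounts of compound), compound 3 gives 72.5 umol/kg, the only number among the three values shown. Compound 2 `CC1CC/C(=N\Nc2cccc(Br)c2)c2ncc(C(=O)O)c(=O)n21` carries bromo where compound 3 carries methyl; in this assay compound 2 reaches only the limit > 320 umol/kg, which is a limit of the assay and not a number. Compound 1 `CC1CC/C(=N\Nc2cccc(C(=O)O)c2)c2nccc(=O)n21` lacks the carboxy on the core but carries carboxy on the aromatic ring; in this assay compound 1 gives the limit > 100 umol/kg, again a limit and not a number.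

Compound 4 `CC1CC/C(=N\Nc2cccc(C(=O)O)c2)c2ncc(C(=O)O)c(=O)n21` differs from compound 3 by carboxy in place of methyl on an aromatic carbon. Within the data shown here, the only measured step, an at least 4.4-fold lower number from compound 2 to compound 3 (0.64 log units; beyond the scatter), touches the same aromatic carbon but not this exchange, so no step speaks to it directly. Compound 1, which alone carries carboxy on that ring, sits at a limit. The author therefore expects a modest rise toward weaker effect, a 2.8-fold higher number from compound 3 to compound 4 (0.44 log units; beyond the scatter), and estimates for compound 4 a value of 200 umol/kg, within 70 umol/kg to 600 umol/kg, with a fair chance that only a limit is reported.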

Compound 4, dose for 50% inhibition: > 100 umol/kg
Compound 4: no number, only a limit (the forecaster's own chance of this, stated with the estimate: 55%); the middle value lies beyond the limit too.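

Carboxy in place of methyl on this aromatic carbon, meta to a large group, gives an at least 1.3-fold higher number from compound 3 to compound 4 (0.13 log units; that floor lies within the scatter), so the exchange brings no lower number, yet a real loss is not established. Of the groups shown at this place, only methyl gives a number in this assay, while bromo and carboxy end at limits, and both compounds with carboxy on this ring sit at the same one: the limit of > 100 umol/kg in this assay, at which 2 of the 4 values shown sit. The steps to compound 4 from compound 2 and from compound 1 cannot be read, as each joins two limits.

As far as these compounds go, how far the true value of compound 4 lies from that of compound 3 stays open. So does how an amine or a methoxy group on this aromatic carbon would read in this assay.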